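Trading one unsaturated chain for another on the phenol core

This account rests on a few compounds, and the source may have more. Where it says the series, first, only, none or still open, it means among the compounds named here.

The measured compounds are few. Compound 1 `C=CCc1cc(-c2ccc(OC)cc2)cc(CC=C)c1O` gives > 100000 nM in a functional assay on HUVEC cells (Homo sapiens) for antiproliferative activity, read by MTT assay, with a stated time of 24 h (on this read-out higher numbers stand for weaker inhibition and lower numbers for stronger inhibition), which is a limit of this assay rather than a number. Compound 3 `C=CC(C)(C)c1cc(-c2ccc(OC)cc2)ccc1O` likewise gives only a limit, > 100000 nM. Among the compounds with values here, compound 2 `C=CC(C)(C)c1cc(-c2cccc([N+](=O)[O-])c2)ccc1O` gives 77000 nM, the only real number in the set; the two other results sit at the limit of > 100000 nM in this assay, at which 2 of the 3 values shown sit. So compound 2 stands alone as the one compound with a measurable value, and it is weak.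

Compound 4 `C=CCc1cc(-c2cccc([N+](=O)[O-])c2)ccc1O` differs from compound 2 by allyl in place of 1,1-dimethylprop-2-en-1-yl on an aromatic carbon. Within the data shown here, no step of this kind has been measured, so the expected shift is modest, within the usual scatter: an estimated 1.2-fold higher number from compound 2 to compound 4 (0.07 log units; within the scatter). Compound 4 is expected to give about 90000 nM, in a range from 35000 nM to 200000 nM.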

Compound 4, half-maximal inhibitory concentration: > 100000 nM
Compound 4 gave a limit, no number; the forecaster's own chance of this, stated with the estimate: 40%; at least 1.1-fold (0.04 log units) between middle value and limit.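

Moving from the 1,1-dimethylprop-2-en-1-yl group to allyl on this aromatic carbon, ortho to the hydroxy group, gives the first step that can be read, an at least 1.2-fold higher number from compound 2 to compound 4 (0.11 log units; that floor lies within the scatter), and only its floor is known. As far as these compounds go, compound 4 gives a limit, not a number, so allyl does not bring a measurable value here and the true size of the step stays open. Only compound 2 still has a number: the limit of > 100000 nM in this assay, at which 3 of the 4 values shown sit. From the compounds shown here alone, whether an amine or a longer chain on this carbon would give a measurable value remains open.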